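This account rests on a few compounds, and the source may have more. Where it says the series, first, only, none or still open, it means among the compounds named here.

Compounds 1 to 3 share one core and differ in the group on an amide-type nitrogen. In an ADME assay on microsomes from liver (Mus musculus, strain CD-1) for metabolic stability, read by LC-MS, tested at 2 uM (a lower number here means that the compound disappears faster, a higher number that the compound lasts longer), compound 1 `CNC(=O)c1ccncc1Nc1cc(-c2ccc3ccn(C)c3c2)c2nccnc2c1` gives 0.45 h, and compound 2 `Cn1cc(CNC(=O)c2ccncc2Nc2cc(-c3ccc4ccn(C)c4c3)c3nccnc3c2)cn1` gives 0.267 h. The step between them is a 1.7-fold lower number from compound 1 to compound 2 (0.23 log units; within the scatter).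

Compound 3 `Cn1ccc2ccc(-c3cc(Nc4cnccc4C(=O)NC4CCNC(=O)C4)cc4nccnc34)cc21` is reported as > 1 h, which is a limit of the assay and not a number. Its standing rests on (the limit of > 1 h in this assay, at which 1 of the 3 values shown sits). The steps leading to it are an at least 2.2-fold higher number from compound 1 to compound 3 (0.34 log units; beyond the scatter) and an at least 3.7-fold higher number from compound 2 to compound 3 (0.57 log units; beyond the scatter).

Compound 4 `CN1CCC(NC(=O)c2ccncc2Nc2cc(-c3ccc4ccn(C)c4c3)c3nccnc3c2)CC1=O` carries methyl in place of hydrogen on an amide-type nitrogen in a ring, so that 2-oxopiperidin-4-yl becomes 1-methyl-2-oxopiperidin-4-yl. For the measured compounds named here, no measured step changes this place. The two steps leading to compound 3 are the nearest guide, and each exchanged a whole group rather than adding one methyl. On these data alone, no step beyond the scatter is therefore expected in this assay, and the direction remains open.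

The expected step is an at least 1.1-fold lower number from compound 3 to compound 4 (0.04 log units; that floor lies within the scatter). Compound 4 is estimated at 0.9 h, with an expected range of 0.4 h to 2 h.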

Compound 4, half-life in the Mus musculus assay: 0.717 h
For compound 4 the middle estimate is 1.3-fold (0.10 log units) above the measured one; the range from low to high includes it.
By their numbers in the Mus musculus assay, from the lowest: compounds 2, 1 and 4 (each within the scatter of the next, the first and the last beyond it). At a limit, above all of these: compound 3.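

Methyl in place of hydrogen on the amide-type nitrogen in the ring is the first change at this position, and in the Mus musculus assay it gives an at least 1.3-fold lower number from compound 3 to compound 4 (0.14 log units; that floor lies within the scatter). The methylated group, 1-methyl-2-oxopiperidin-4-yl, still shows a 2.7-fold higher number from compound 2 to compound 4 (0.43 log units; beyond the scatter), while the comparison with the small methyl amide shows a 1.6-fold higher number from compound 1 to compound 4 (0.20 log units; within the scatter). In a physicochemical assay for solubility, read by spectrophotometry, measured as kinetic solubility, at pH 8, tested at 500 uM (a lower number here means a less soluble compound, a higher number a more soluble compound), compound 3 gives 242 ug/mL and compound 4 gives 48 ug/mL. The same change has a clearer cost in the physicochemical assay: the measured solubility of compound 3, 242 ug/mL, and of compound 4, 48 ug/mL, a 5.0-fold lower number (0.70 log units; beyond the scatter)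

On these data alone, compound 3 stands at a limit of the assay, so the true size of its step to the methylated compound in the Mus musculus assay remains unresolved: the limit of > 1 h in the Mus musculus assay, at which 1 of the 4 values shown sits. How ethyl, a longer chain or a chain ending in an amine on this ring nitrogen would read in the Mus musculus assay and the physicochemical assay remains open.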